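A few compounds are considered here, and "the series" means these few. Any claim that something is new, unique, unknown or untested is made for them only; others in the source may bear on it.

Compound 1, `CCCSc1nc2nc(C)cc(N3CC[C@@H](C)[C@@H](N(C)c4ncnc5[nH]ccc45)C3)n2n1`, gives 51200 nM in a functional assay on BGC-823 cells (Homo sapiens) for inhibition, read by MTT assay, with a stated time of 72 h; a higher number here means a weaker inhibitor, a lower number a stronger inhibitor.
Compound 2, `Cc1cc(N2CC[C@@H](C)[C@@H](N(C)c3ncnc4[nH]ccc34)C2)n2nc(SCc3ccccc3Br)nc2n1`, gives 81100 nM in this assay.
Compound 3, `Cc1cc(N2CC[C@@H](C)[C@@H](N(C)c3ncnc4[nH]ccc34)C2)n2nc(SCc3ccc(Cl)cc3)nc2n1`, gives 26300 nM in this assay.

All three share one core and differ only in the group on a saturated chain carbon bound to a sulfur. Compound 3 has the lowest number of the three, but its gap to compound 1 is within the scatter, so only its step from compound 2 stands out: a 3.1-fold lower number from compound 2 to compound 3 (0.49 log units; beyond the scatter). The other two steps were a 1.6-fold higher number from compound 1 to compound 2 (0.20 log units; within the scatter) and a 1.9-fold lower number from compound 1 to compound 3 (0.29 log units; within the scatter).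

Compound 4, `Cc1cc(N2CC[C@@H](C)[C@@H](N(C)c3ncnc4[nH]ccc34)C2)n2nc(SCc3ccc(F)c(Cl)c3)nc2n1`, has not yet been measured. It differs from compound 3 as follows: 3-chloro-4-fluorophenyl in place of 4-chlorophenyl on a saturated chain carbon bound to a sulfur. Among the measured compounds shown here, no measured step swaps one substituted phenyl for another with a single extra halogen; the nearest comparison, compound 2 to compound 3, changed both the halogen and its position, and was only modest. A step within the scatter is therefore expected from compound 3 to compound 4 in this assay, namely a 1.1-fold lower number from compound 3 to compound 4 (0.02 log units; within the scatter). Compound 4 is estimated at 25000 nM, between 10000 nM and 60000 nM.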

Compound 4, half-maximal inhibitory concentration: 98900 nM
For compound 4 the middle estimate is 4.0-fold (0.60 log units) below the measured one, outside the stated range (above it).
By their numbers in this assay, from the lowest: compounds 3, 1, 2 and 4 (each within the scatter of the next, the first and the last beyond it).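

At this position, changing only the halogens on the phenyl ring is enough to give a 3.8-fold higher number from compound 3 to compound 4 (0.58 log units; beyond the scatter) in this assay; this shows that such a small change can matter as much as the earlier 3.1-fold lower number from compound 2 to compound 3 (0.49 log units; beyond the scatter) did. The other two new steps, a 1.2-fold higher number from compound 2 to compound 4 (0.09 log units; within the scatter) and a 1.9-fold higher number from compound 1 to compound 4 (0.29 log units; within the scatter), both stay within the scatter, so 3-chloro-4-fluorophenyl cannot be ranked against 2-bromophenyl or ethyl. The 4-chlorophenyl of compound 3 therefore stands clear of both other halogenated phenyl groups, but not of the ethyl of compound 1.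

No evidence is available on what lies behind the step from compound 3 to compound 4. The added fluorine and the altered chlorine placement arrive together, so a plain phenyl or a 4-fluorophenyl group would be needed to tell their contributions apart.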